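Adding an amino group to compound 3

The source may hold more compounds than are shown below. What is called first, only, known or untested is meant among the compounds shown, and "the series" means these compounds.

Measured in a functional assay on HCT-116 cells (Homo sapiens) for inhibition; a lower number here means a stronger inhibitor, a higher number a weaker inhibitor:
Compound 1 `CC(C)=CC(=O)OCc1cc(=O)oc2ccc(Cl)cc12`: > 10 ug/mL
Compound 2 `COc1ccc2c(COC(=O)C=C(C)C)cc(=O)oc2c1`: > 10 ug/mL
Compound 3 `COc1cc2oc(=O)cc(COC(=O)/C=C/c3ccccc3)c2cc1OC`: > 10 ug/mL

Compound 3 gives > 10 ug/mL, which is a limit and not a number. It shares this position with the other two compounds: the limit of > 10 ug/mL in this assay, at which 3 of the 3 values shown sit. Going by the values given here, no measured step is therefore available as a guide. Compound 4 `COc1cc2oc(=O)cc(COC(=O)/C=C/c3ccc(N)cc3)c2cc1OC` carries amino in place of hydrogen on an aromatic carbon, para to a large group (amino in place of hydrogen on an aromatic carbon), so that phenyl becomes 4-aminophenyl. In this assay a small step towards stronger inhibition is expected, perhaps none beyond the scatter, and the result may again be only a limit. The expected change is an at least 1.1-fold lower number from compound 3 to compound 4 (0.04 log units; that floor lies within the scatter). The estimate for compound 4 is 9 ug/mL, with an expected range of 3 ug/mL to 25 ug/mL.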

Compound 4, half-maximal inhibitory concentration: > 10 ug/mL
Compound 4 ended at the assay's limit (the forecaster's own chance of this, stated with the estimate: 55%); middle value at least 1.1-fold (0.04 log units) away from the limit.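

Compound 3 and compound 4 both sit at a limit and not at a number, so no step between them can be read: the limit of > 10 ug/mL in this assay, at which 4 of the 4 values shown sit.

The compounds shown leave open whether amino in place of hydrogen changes inhibition at all, and how strong any of these compounds actually is.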